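Replacing the imidazole in the lactam series

A few compounds are considered here, and "the series" means these few. Any claim that something is new, unique, unknown or untested is made for them only; others in the source may bear on it.

Compound 3 `CC(C)C(c1ncc[nH]1)c1ccc(-c2ccc3cccc(F)c3c2)[nH]c1=O` gives in an ADME assay on microsomes from liver (Homo sapiens) for metabolic stability (a higher number here means that the compound lasts longer, a lower number that the compound disappears faster), only a limit, < 0.0667 h. Compound 1 `CC(C)C(Cc1nnc[nH]1)c1ccc(-c2ccc3cccc(F)c3c2)[nH]c1=O` gives 0.307 h and compound 2 `Cc1nc(C(c2ccc(-c3ccc4cccc(F)c4c3)[nH]c2=O)C(C)C)[nH]c1C` gives 0.268 h. The steps of an at least 4.6-fold lower number from compound 1 to compound 3 (0.66 log units; beyond the scatter) and an at least 4.0-fold lower number from compound 2 to compound 3 (0.60 log units; beyond the scatter) both end at the limit of < 0.0667 h in this assay, at which 1 of the 3 values shown sits, and compound 3 thus stands at the short end of the series. Compound 4 `CC(C)C(CC(N)=O)c1ccc(-c2ccc3cccc(F)c3c2)[nH]c1=O` differs from compound 3 by carbamoylmethyl in place of 1H-imidazol-2-yl on a saturated chain carbon bound to an aromatic carbon and a saturated chain carbon; the 1H-imidazol-2-yl leaves, as it entered in the two measured steps, while what enters here is carbamoylmethyl. Those two steps bear on the change and both were at least modest. Compound 4 is expected to return toward the level of compound 1 and compound 2, a step of an at least 4.4-fold higher number from compound 3 to compound 4 (0.65 log units; beyond the scatter). The estimate for compound 4 is 0.3 h, spanning 0.1 h to 0.8 h.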

Compound 4, half-life: < 0.0667 h
Compound 4 ended at the assay's limit; the forecaster's own chance of this, stated with the estimate: 20%; middle value at least 4.4-fold (0.65 log units) away from the limit.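

In this assay compound 4 gives < 0.0667 h, which is a limit of the assay and not a number. The steps of an at least 4.6-fold lower number from compound 1 to compound 4 (0.66 log units; beyond the scatter) and an at least 4.0-fold lower number from compound 2 to compound 4 (0.60 log units; beyond the scatter) show that the short end is not confined to the unsubstituted imidazole; the first step, carbamoyl in place of 4H-1,2,4-triazol-3-yl, also shows that the chain carbon carrying the group is not enough to hold the number. The step between compound 3 and compound 4 cannot be read, and both now sit at the floor: the limit of < 0.0667 h in this assay, at which 2 of the 4 values shown sit.

From the compounds shown here alone, how far compound 3 and compound 4 lie beyond that limit stays open. So does whether a carboxylic acid or an amine at the end of the same chain would behave like the carbamoyl or like the 4H-1,2,4-triazol-3-yl.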